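A few compounds are considered here, and "the series" means these few. Any claim that something is new, unique, unknown or untested is made for them only; others in the source may bear on it.

Measured compounds:
- compound 1, `CC(Sc1nnc(-c2ccncc2)s1)C(=O)Nc1ccccc1Cl`: in an ADME assay on BHK-21 cells (Mesocricetus auratus) for cytotoxicity, with a stated time of 3 days (a lower number here means that less compound is tolerated, a higher number that more compound is tolerated), compound 1 gives > 50000 nM, which is a limit of the assay and not a number.
- compound 2, `CC(Sc1nnc(-c2ccncc2)s1)C(=O)NCc1ccccc1Cl`: in this assay compound 2 gives > 50000 nM, again a limit and not a number.

On the numbers shown, compound 2 therefore stands only at a limit, and the one other value shown is a limit as well (the limit of > 50000 nM in this assay, at which 2 of the 2 values shown sit). For the measured compounds named here, the single measured step, a step that the two limits leave unreadable from compound 1 to compound 2, is left unreadable by the two limits, so it tells nothing about the size or direction of a change on the amide-type nitrogen.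

Compound 3, `CC(Sc1nnc(-c2ccncc2)s1)C(=O)Nc1ccccc1`, has not yet been measured. It differs from compound 2 by phenyl in place of 2-chlorobenzyl on an amide-type nitrogen. Going by the values given here, no measured step bears on this change in a readable way. With both measured compounds sitting at the limit (the limit of > 50000 nM in this assay, at which 2 of the 2 values shown sit), the plain expectation is that compound 3 will also be tolerated up to the limit, with no step beyond the scatter expected in this assay.

The estimate for compound 3 is 50000 nM, with a range from 20000 nM to 100000 nM. This estimate corresponds to an expected step of a number no higher from compound 2 to compound 3 (the limit leaves the size open).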

Compound 3, half-maximal cytotoxic concentration: > 50000 nM
Compound 3 ended at the assay's limit; the forecaster's own chance of this, stated with the estimate: 80%; the middle value lies on the limit itself.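

Compound 3 sits at the same limit as compound 1 and compound 2, so the steps among these three compounds cannot be read, in size or in direction: the limit of > 50000 nM in this assay, at which 3 of the 3 values shown sit.

The compounds shown leave open how far each of compound 1, compound 2 and compound 3 lies from that limit, and whether these changes alter tolerance at all.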